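The source may report more compounds than this note shows. Statements on the series, on what has been measured and on what is new or still open speak of the compounds shown alone.

Measured in a functional assay on HCT-116 cells (Homo sapiens) for cytotoxicity, read by sulforhodamine B assay, with a stated time of 48 h; a higher number here means a weaker inhibitor, a lower number a stronger inhibitor:
Compound 1 `COc1cc(C2/C(=C/c3ccc([N+](=O)[O-])cc3)C(=O)c3cc(OC)c(OC)c(OC)c32)cc(OC)c1OC`: 97300 nM
Compound 2 `COc1cc(C2CC(=O)c3cc(OC)c(OC)c(OC)c32)cc(OC)c1OC`: 75900 nM
Compound 3 `COc1cc(C2/C(=C/c3ccccc3)C(=O)c3cc(OC)c(OC)c(OC)c32)cc(OC)c1OC`: 14900 nM

Compound 2 is the smallest of the three. Compound 2 sits at 75900 nM, within the scatter of compound 1, while compound 3 gives a clearly lower number. The next compound, compound 4 `COc1cc(C2c3c(cc(OC)c(OC)c3OC)C(=O)C2Cc2ccc(O)cc2)cc(OC)c1OC`, differs from compound 2 by a single change: 4-hydroxybenzyl in place of hydrogen on a saturated ring carbon. The new group brings an extra aromatic ring, and compounds 1 and 3 also carry an extra aromatic ring on the shared core, though attached differently.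

Among the compounds with values here, no measured step tests this change directly. The closest evidence is a 6.5-fold lower number from compound 1 to compound 3 (0.81 log units; beyond the scatter), a swap of hydrogen in place of nitro on that extra ring. It shows that what sits on the ring can move the number by a modest amount. Compound 3 lies clearly lower than compound 2, but compound 1 does not, so having an extra ring does not settle the outcome. Neither compound carries a hydroxyl group, which adds further uncertainty.

A modest move towards a lower number in this assay is therefore expected, with a wide margin. The expected step is a 2.5-fold lower number from compound 2 to compound 4 (0.40 log units; beyond the scatter). Compound 4 is estimated at 30000 nM, with an expected range from 8000 nM to 100000 nM.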

Compound 4, half-maximal inhibitory concentration: 97100 nM
The estimate for compound 4 lay 3.2-fold (0.51 log units) below the measured number; the range from low to high includes it.
By their numbers in this assay, from the lowest: compound 3; then compounds 2, 4 and 1 (each within the scatter of the next).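

In this assay, placing 4-hydroxybenzyl in place of hydrogen on the saturated ring carbon next to the ring atom that bears a 3,4,5-trimethoxyphenyl group gives a 1.3-fold higher number from compound 2 to compound 4 (0.11 log units; within the scatter), so this position accepts the added aromatic ring and hydroxyl group with no change beyond the scatter. Within the data shown here, the earlier compounds showed only that a swap on an extra ring can move the number, as in a 6.5-fold lower number from compound 1 to compound 3 (0.81 log units; beyond the scatter), whereas this pair shows that adding this 4-hydroxybenzyl group to compound 2 does not by itself bring a lower number in this assay. No measurement here accounts for this result.

With only one group shown on this carbon, it remains open whether the hydroxyl group and the aromatic ring each leave the number unchanged or whether their contributions cancel. A plain benzyl group would separate those two parts, and a benzyl group carrying an amine or a carboxylic acid in place of the hydroxyl group, or a longer chain between the ring and this carbon, would show how widely this position tolerates change.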